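The source may report more compounds than this note shows. Statements on the series, on what has been measured and on what is new or still open speak of the compounds shown alone.

In a functional assay on DU-145 cells (Homo sapiens) for inhibition, read by trypan blue exclusion, with a stated time of 96 h (a lower number here means a stronger inhibitor of growth, a higher number a weaker inhibitor of growth), compound 1 `O=C(/C(=C\c1ccc(O)c([N+](=O)[O-])c1)SCc1ccc(Cl)cc1)c1ccc(Cl)cc1` gives 10000 nM. Compound 2 `Cc1cc(C)cc(/C=C(/SCc2ccc(Cl)cc2)C(=O)c2ccc(Cl)cc2)c1` gives 10000 nM, which leaves the two level. Compound 3 `Cc1ccc(S/C(=C/c2ccc(O)c([N+](=O)[O-])c2)C(=O)c2ccc(Cl)cc2)cc1` has not yet been measured. It keeps the core of compound 1 and differs in one group: 4-methylphenyl in place of 4-chlorobenzyl on a sulfur. In words, 4-methylphenyl stands in place of 4-chlorobenzyl on a sulfur. Among the measured compounds shown here, only one measured step exists, and it bears on this change only indirectly: no change at the digits printed from compound 1 to compound 2 (within the scatter). For the measured compounds named here, that step put 3,5-dimethylphenyl in place of 4-hydroxy-3-nitrophenyl, elsewhere in the molecule, so no measurement yet tests a change on the sulfur. The data favour no direction, so the weak expectation is no step beyond the scatter in this assay. The expected step is no change at the digits printed from compound 1 to compound 3 (within the scatter). The estimate for compound 3 is 10000 nM, within an expected range of 2000 nM to 25000 nM.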

Compound 3, concentration for 50% growth inhibition: 10000 nM
Compound 3: middle estimate and measured number agree at the digits printed; the range from low to high includes it.
By their numbers in this assay, from the lowest: compounds 1, 2 and 3 (each within the scatter of the next).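

Among the compounds shown here, this is the first measured change on the sulfur. In this assay, for the compounds shown here, the step of no change at the digits printed from compound 1 to compound 3 (within the scatter) shows that the 4-chlorobenzyl can give way to 4-methylphenyl, a group of carbon only that carries no chlorine, without the reading leaving the scatter, and compound 3 gives 10000 nM, level with the earlier compounds. No independent measurement offers an explanation for this flat result.

The compounds shown leave open whether any group on the sulfur can move the number at all, for instance a longer chain ending in an amine or a carboxylic acid. They also leave open whether 4-methylphenyl on the sulfur would give the same reading alongside the 3,5-dimethylphenyl of compound 2.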